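The source may report more compounds than this note shows. Statements on the series, on what has been measured and on what is new or still open speak of the compounds shown alone.

Measured in a functional assay on liver (Rattus norvegicus, strain Sprague-Dawley) for inhibition, with a stated time of 1 h; on this read-out lower numbers stand for stronger inhibition and higher numbers for weaker inhibition:
- compound 1 `COc1cc(C2Oc3cc([C@H]4Oc5cc(O)cc(O)c5C(=O)[C@@H]4O)ccc3OC2COC(=O)c2cc(OC)c(OC)c(OC)c2)ccc1O`: 25700 nM
- compound 2 `COc1cc(C2Oc3cc([C@H]4Oc5cc(O)cc(O)c5C(=O)[C@@H]4O)ccc3OC2COC(=O)c2ccccc2)ccc1O`: 12700 nM

Compound 1 holds the higher of the two numbers, 25700 nM. Compound 3 `COc1cc(C2Oc3cc([C@H]4Oc5cc(O)cc(O)c5C(=O)[C@@H]4O)ccc3OC2COC(=O)/C=C/c2ccc(Cl)cc2)ccc1O` is the next to be measured, and it keeps the core of compound 1 but has 2-(4-chlorophenyl)ethenyl in place of 3,4,5-trimethoxyphenyl on a carbonyl carbon. Among the measured compounds shown here, one measured step bears on this change, since the same group leaves from the same place with phenyl entering: a 2.0-fold lower number from compound 1 to compound 2 (0.31 log units; beyond the scatter). That step is modest. For the measured compounds named here, no measured compound carries 2-(4-chlorophenyl)ethenyl, so the direction is uncertain. A similarly modest move to a lower number is expected, a 2.0-fold lower number from compound 1 to compound 3 (0.30 log units; within the scatter). Compound 3 is estimated at 13000 nM, with an expected range of 5000 nM to 32000 nM.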

Compound 3, half-maximal inhibitory concentration: 12000 nM
The estimate for compound 3 lay 1.1-fold (0.03 log units) above the measured number, and the stated range covers the measured number.
By their numbers in this assay, from the lowest: compounds 3 and 2 (each within the scatter of the next); then compound 1.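

Replacing 3,4,5-trimethoxyphenyl on a carbonyl carbon with 2-(4-chlorophenyl)ethenyl in this assay gives a 2.1-fold lower number from compound 1 to compound 3 (0.33 log units; beyond the scatter) and so provides a second entering group that moves the number the same way as phenyl. Set against phenyl, the same group gives a 1.1-fold lower number from compound 2 to compound 3 (0.02 log units; within the scatter) and so leaves compound 2 and compound 3 without an order. Nothing available explains either step.

Open, from the compounds shown here alone, is whether an amine or a carboxylic acid at this place would keep the number in this range. Also open, going by these compounds, is whether a longer chain would do so.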